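Notes on a benzyloxy variant of compound 1

The compounds below may be only part of what the source reports. "The series", "measured", "known", "first", "only" and "open" are said of these compounds alone.

The compounds were measured in an assay on isolated protein for agonist activity at Bile acid receptor (Homo sapiens), read by AlphaScreen, with a stated time of 30 min; on this read-out higher numbers stand for an effect only at larger amounts of compound and lower numbers for an effect already at smaller amounts. Compound 1 `Cc1ccccc1-n1nc(C)c2c1NC(=O)[C@H](C)S[C@@H]2c1ccc(-c2ccoc2)cc1` gives 3500 nM, the highest of the three numbers. Compound 2 `Cc1nn(-c2ccccc2C(F)(F)F)c2c1C(c1ccc(Oc3ccccc3)cc1)SC(C)C(=O)N2` gives 2000 nM, which lies within the scatter of compound 1. Compound 3 `CCCc1ccccc1-n1nc(C)c2c1NC(=O)[C@H](C)S[C@@H]2c1ccc(Oc2ccccc2)cc1` gives 1100 nM, a lower number than compound 1 by more than the scatter. Compound 4 `Cc1ccccc1-n1nc(C)c2c1NC(=O)[C@H](C)S[C@@H]2c1ccc(OCc2ccccc2)cc1` is not yet measured; it differs from compound 1 by benzyloxy in place of furan-3-yl on an aromatic carbon. Among the measured compounds shown here, no pair of measured compounds differs in one place, so the size of such a step is unknown, and compounds 2 and 3 are not single-place changes from compound 1. The expected step, a 1.6-fold lower number from compound 1 to compound 4 (0.20 log units; within the scatter), is small, toward a lower number, and likely within the scatter. Compound 4 is estimated at 2200 nM, in a range from 700 nM to 7000 nM.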

Compound 4, half-maximal effective concentration: "not active" (no number reported)
The entry for compound 4 holds no number; there is nothing to compare the estimate with.
By their numbers in this assay, from the lowest: compounds 3, 2 and 1 (each within the scatter of the next, the first and the last beyond it).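

Among the compounds shown here, compound 4 is reported as not active with no number in this assay, so no step from compound 1 to compound 4 can be read. No evidence on hand bears on this result. The compounds shown leave open how large the effect of benzyloxy in place of furan-3-yl is.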